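Fluoro for Chloro on the Hydrazone Aryl Ring

A few compounds are considered here, and "the series" means these few. Any claim that something is new, unique, unknown or untested is made for them only; others in the source may bear on it.

Compound 1 `O=C(N/N=C\c1ccc(Cl)cc1)C1=C(Cl)c2ccccc2CCC1`: 2300 nM
Compound 2 `O=C(N/N=C\c1ccc(F)cc1)C1=C(Cl)c2ccccc2CCC1`: 1300 nM
Compound 3 `Cc1cc2c(cc1C)C(Cl)=C(C(=O)N/N=C\c1ccc(Cl)cc1)CCC2`: 1600 nM

Three compounds have been run in a functional assay on HeLa cells (Homo sapiens) for inhibition, read by sulforhodamine B assay, with a stated time of 48 h; on this read-out lower numbers stand for stronger inhibition of growth and higher numbers for weaker inhibition of growth. Compound 1 gives 2300 nM, and in this assay compound 2 gives 1300 nM. Compound 2 differs from compound 1 by fluoro in place of chloro on an aromatic carbon, and this change produced a 1.8-fold lower number from compound 1 to compound 2 (0.25 log units; within the scatter). Compound 3 carries a different core; the difference between the two cores is not broken down here. In this assay compound 3 gives 1600 nM, which sits within the scatter of both compound 1 and compound 2.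

Compound 4 `Cc1cc2c(cc1C)C(Cl)=C(C(=O)N/N=C\c1ccc(F)cc1)CCC2` has not yet been measured. It differs from compound 3 by fluoro in place of chloro on an aromatic carbon, the same change that separates compound 2 from compound 1, at the same place on the aromatic ring. Because the earlier change gave only a 1.8-fold lower number from compound 1 to compound 2 (0.25 log units; within the scatter), a step of similar small size is expected from compound 3 to compound 4, namely a 1.6-fold lower number from compound 3 to compound 4 (0.20 log units; within the scatter). On that basis compound 4 is estimated to give 1000 nM in this assay, with a likely range from 500 nM to 2500 nM.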

Compound 4, concentration for 50% growth inhibition: 2200 nM
Estimate against measurement, compound 4: 2.2-fold (0.34 log units) below; low and high end bracket the measured number.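

In this assay, 4-fluorophenyl in place of 4-chlorophenyl on the core of compound 3 gives a 1.4-fold higher number from compound 3 to compound 4 (0.14 log units; within the scatter), so on neither core does this change produce a step that stands clear of the scatter. The two steps have opposite signs on paper, yet the gap between them is no larger than repeated measurements could produce: the same change on two cores in this assay, a 1.8-fold lower number (0.25 log units; within the scatter) from compound 1 to compound 2 and a 1.4-fold higher number (0.14 log units; within the scatter) from compound 3 to compound 4, 2.4-fold (0.39 log units) apart, within the scatter of two such steps. This shows that the change is small on both cores and that no dependence on the core can be read from these four compounds, but it does not show that the change carries over exactly or that it has no effect at all, and a modest difference between the cores could lie hidden in steps this small.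

The compounds shown leave open how a methoxy group, a nitrile or an amine at that place on the aromatic ring would read on these two cores. They also leave open whether the chloro to fluoro change stays this small on any other core.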